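The source may hold more compounds than are shown below. What is called first, only, known or untested is meant among the compounds shown, and "the series" means these compounds.

Measured compounds:
Compound 1, `N#Cc1c(Nc2ccc(O)cc2)nc(SCC(=O)Nn2c(COc3ccc(Cl)cc3Cl)nc3ccccc3c2=O)nc1-c1ccc(Cl)cc1` — in a functional assay on the whole organism (strain albino) for inhibition, with Rattus norvegicus as the target, read by paw edema, with stated times of 1 h and 3 h, at a dose of 50 mg/kg by the oral route (on this read-out higher numbers stand for a stronger effect at the one dose given and lower numbers for a weaker effect), compound 1 gives 61.4%.
Compound 2, `N#Cc1c(Nc2ccccc2)nc(SCC(=O)Nn2c(COc3ccc(Cl)cc3Cl)nc3ccccc3c2=O)nc1-c1ccc(O)cc1` — in this assay compound 2 gives 77.2%.

Of these two numbers, compound 2 holds the higher one; compound 1 lies below it by a margin beyond the usual scatter. Going by the values given here, the two compounds are not a single-change pair, since they differ in two places, so their values show only that compound 2 is the stronger of the pair at the dose used.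

The next compound, compound 3, `N#Cc1c(Nc2ccc(O)cc2)nc(SCC(=O)Nn2c(COc3ccc(Cl)cc3Cl)nc3ccccc3c2=O)nc1-c1ccc(O)cc1`, is built from compound 2 by one change: hydroxy in place of hydrogen on an aromatic carbon. The new hydroxy sits on an aromatic carbon of a six-membered aromatic ring of carbon only, turning the anilino group into a (4-hydroxyphenyl)amino group. Compound 1 already carries such a (4-hydroxyphenyl)amino group, yet gives the lower of the two measured numbers, though it also lacks the hydroxy that compound 2 carries on its other ring. Among the compounds with values here, with no measured step for this single change, the expectation for this assay is a step from compound 2 to compound 3 of a number 5.2 percentage points lower from compound 2 to compound 3 (within the scatter), that is, none beyond the scatter. Compound 3 is therefore expected at 72%, within a range from 58% to 84%.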

Compound 3, a percentage reported as inhibition, in the whole organism at one dose (the size of the read-out at that dose, not a potency): 56.1%
For compound 3 the middle estimate is 15.9 percentage points above the measured one; the measured number lies below the stated range.
By their numbers in this assay, from the lowest: compounds 3 and 1 (each within the scatter of the next); then compound 2.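

In this assay, placing a hydroxy on the anilino ring of compound 2 to give the (4-hydroxyphenyl)amino group of compound 3 produces a number 21.1 percentage points lower from compound 2 to compound 3 (beyond the scatter). Going by these compounds alone, this is the first single-change step, and it shows that this aromatic carbon is not indifferent to substitution when the other ring carries a hydroxy. With the (4-hydroxyphenyl)amino group kept in place, putting hydroxy in place of chloro on the other ring gives a number 5.3 percentage points lower from compound 1 to compound 3 (within the scatter), so that exchange cannot be told apart from repeated-measurement noise, and nothing measured here gives a cause for either step.

The compounds shown leave open whether this weaker effect is specific to hydroxy, or whether a methoxy group or an amine on the same aromatic carbon would give a similar number. They also leave open whether the step would hold at other doses, since each number gives the size of the effect at a single dose rather than a potency.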